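A few compounds are considered here, and "the series" means these few. Any claim that something is new, unique, unknown or untested is made for them only; others in the source may bear on it.

Measured in an assay on CHO cells for agonist activity at Free fatty acid receptor 1 (Homo sapiens), read by FLIPR; a higher number here means that more compound is needed for the effect, a lower number that less compound is needed:
Compound 1 `O=C(O)COc1ccc(OCc2nnc(-c3ccccc3)o2)cc1F` — the assay reports a limit, > 10000 nM.
Compound 2 `Cc1nc(-c2ccccc2)sc1COc1ccc(S(=O)(=O)CC(=O)O)cc1` — 370 nM.
Compound 3 `Cc1nc(-c2ccccc2)sc1COc1ccc2c(c1)OCC2CC(=O)O` — 102 nM.

Compound 3 has the lowest of the two numbers in this assay; compound 2 gives a higher number, with a gap that is beyond the scatter. For compound 1 only a limit is shown, and at that limit one of the three values sits (the limit of > 10000 nM in this assay, at which 1 of the 3 values shown sits).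

Compound 4 `COc1ccc(-c2nc(C)c(COc3ccc4c(c3)OCC4CC(=O)O)s2)cc1` differs from compound 3 by methoxy in place of hydrogen on an aromatic carbon. For the measured compounds named here, no measured pair shows this change, so the expected step of a 1.5-fold lower number from compound 3 to compound 4 (0.16 log units; within the scatter) is a small one, about within the scatter, if anything toward a lower number. Compound 4 is therefore estimated at 70 nM, with a range from 25 nM to 250 nM.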

Compound 4, half-maximal effective concentration: 156 nM
For compound 4 the middle estimate is 2.2-fold (0.35 log units) below the measured one; the range from low to high includes it.
By their numbers in this assay, from the lowest: compounds 3 and 4 (each within the scatter of the next); then compound 2. At a limit, above all of these: compound 1.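

In this assay the change from phenyl to 4-methoxyphenyl gives a 1.5-fold higher number from compound 3 to compound 4 (0.18 log units; within the scatter) and so shows that this position carries a methoxy without a shift beyond the scatter. This is the only comparison among the compounds shown that differs in one place, so it is the first direct reading of any single change in the series. No measured property shown here bears on this step.

For the compounds shown here, only one group at this position can be compared. From the compounds shown here alone, whether fluorine, an amine or a longer alkoxy chain in the same place would give a step beyond the scatter remains open.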